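Compound 3 to compound 4: butyl for methylsulfanyl

The source may report more compounds than this note shows. Statements on the series, on what has been measured and on what is new or still open speak of the compounds shown alone.

In a physicochemical assay for solubility, in phosphate buffer, with a stated time of 18 h (on this read-out lower numbers stand for lower solubility and higher numbers for higher solubility), compound 1 `CC(C)c1ncc2c(N)c(C#N)c(N)nc2n1` reads > 1000000 nM, which is a limit of the assay and not a number. Among the compounds with values here, compound 2 `N#Cc1c(N)nc2nc(C3CCCC3)ncc2c1N` gives 89000 nM, and compound 3 `CSc1nc(C(C)(C)C)nc2nc(N)c(C#N)c(N)c12` stands lowest of the numbers so far at 14000 nM. Compound 4 `CCCCc1nc(C(C)(C)C)nc2nc(N)c(C#N)c(N)c12` carries butyl in place of methylsulfanyl on an aromatic carbon. Within the data shown here, the only measured step, an at least 11-fold lower number from compound 1 to compound 2 (1.05 log units; beyond the scatter), has cyclopentyl in place of isopropyl. It involves other groups, so it serves only as a loose guide to direction and size. The expected change in this assay is a 3.5-fold lower number from compound 3 to compound 4 (0.54 log units; beyond the scatter), a lower number, beyond the scatter but smaller than that measured step. For compound 4 the estimated value is 4000 nM, with an expected range of 1000 nM to 12000 nM.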

Compound 4, solubility: 6000 nM
The estimate for compound 4 lay 1.5-fold (0.18 log units) below the measured number; the range from low to high includes it.
By their numbers in this assay, from the lowest: compound 4; then compound 3; then compound 2. At a limit, above all of these: compound 1.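

In this assay, within the data shown here, a 2.3-fold lower number from compound 3 to compound 4 (0.37 log units; beyond the scatter) gives the first reading at the aromatic carbon meta to a tert-butyl group, where the earlier step involved isopropyl and cyclopentyl instead. With the rest of the structure unchanged, butyl in place of methylsulfanyl shifts the number by a modest but real amount. Nothing shown gives a reason for this step.

Open, going by these compounds, is how an amine or a carboxylic acid at this carbon would read, and whether a longer chain would continue the direction seen with butyl. Also open, on these data alone, is whether the step would hold with isopropyl or cyclopentyl in place of tert-butyl.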